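A few compounds are considered here, and "the series" means these few. Any claim that something is new, unique, unknown or untested is made for them only; others in the source may bear on it.

Measured compounds and their values:
- Compound 1 `OC[C@H]1O[C@@H](n2cnc3c(NCc4ccccc4Br)ncnc32)[C@H](O)[C@@H]1O` gives > 166000 nM, a limit of the assay.
- Compound 2 `COc1ccccc1CNc1ncnc2c1ncn2[C@@H]1O[C@H](CO)[C@@H](O)[C@H]1O` gives > 166000 nM, also a limit.
- Compound 3 `OC[C@H]1O[C@@H](n2cnc3c(NCc4cc(F)cc(F)c4)ncnc32)C(O)C1O` gives > 166000 nM, again a limit.

In a functional assay on MCF cells (Homo sapiens) for antiproliferative activity, with a stated time of 72 h (on this read-out higher numbers stand for weaker inhibition and lower numbers for stronger inhibition), compound 2 stands only at a limit, and the two other values shown are limits as well (the limit of > 166000 nM in this assay, at which 3 of the 3 values shown sit). For the measured compounds named here, the single step between measured compounds, a step that the two limits leave unreadable from compound 1 to compound 2, gives no readable size. Compound 4 `OC[C@H]1O[C@@H](n2cnc3c(NCc4cc(O)cc(O)c4)ncnc32)[C@H](O)[C@@H]1O` differs from compound 2 by 3,5-dihydroxyphenyl in place of 2-methoxyphenyl on a saturated chain carbon bound to a nitrogen on an aromatic ring. With no readable step to lean on, the expected step that the limit leaves unreadable from compound 2 to compound 4 is most likely to end at a limit again, in no readable direction. Compound 4 is therefore estimated at 200000 nM, within 50000 nM to 1000000 nM.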

Compound 4, half-maximal inhibitory concentration: > 166000 nM
Compound 4 ended at the assay's limit; the forecaster's own chance of this, stated with the estimate: 85%; the middle value is on the limit's open side.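

Compound 4 gives > 166000 nM, which is a limit, so the steps to compound 4 from compound 1 and compound 2 cannot be read. The compounds shown leave open how strongly any of them inhibits, because all of them stop at the same point: the limit of > 166000 nM in this assay, at which 4 of the 4 values shown sit.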